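Pyrrolidinone in place of the succinimide: compound 3

A few compounds are considered here, and "the series" means these few. Any claim that something is new, unique, unknown or untested is made for them only; others in the source may bear on it.

Measured so far:
compound 1 `CCc1cnc(N2CCC(c3nc(COc4ccc(/C=C5\CC(=O)N(CCN)C5=O)cc4F)cs3)CC2)nc1`: "not determined" (no result reported) in a functional assay on cells for agonist activity at Glucose-dependent insulinotropic receptor (Homo sapiens), read by a luciferase reporter, with a stated time of 6 h; on this read-out higher numbers stand for an effect only at larger amounts of compound and lower numbers for an effect already at smaller amounts
compound 2 `CCc1cnc(N2CCC(c3nc(COc4ccc(/C=C5\CC(=O)N(c6ccccc6)C5=O)cc4F)cs3)CC2)nc1`: 82 nM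

Compound 1 stands nowhere on the numbers, since no result is recorded for it. Compound 2 is the only anchor in this assay, giving 82 nM. Compound 3 `CCc1cnc(N2CCC(c3nc(COc4ccc(/C=C5\CCNC5=O)cc4F)cs3)CC2)nc1` differs from compound 1 by a group of 7 heavy atoms (5 carbon, 1 nitrogen, 1 oxygen; one five-membered non-aromatic ring with 1 hetero atom) in place of a group of 11 heavy atoms (7 carbon, 2 nitrogen, 2 oxygen; one five-membered non-aromatic ring with 1 hetero atom), on an aromatic carbon. Within the data shown here, no step between measured compounds is available, so the size of the change cannot be read from data; given that compound 3 lacks the substituted imide of compound 2, a shift toward weaker activity in this assay is expected. Compound 3 is estimated at 500 nM, within 100 nM to 3000 nM.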

Compound 3, half-maximal effective concentration: 100 nM
Compound 3: the middle estimate sits 5.0-fold (0.70 log units) above what was measured; measured number inside the range.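

No new step can be read from compound 3 and compound 1 in this assay. The compounds shown leave open what the ring exchange alone does to activity. No evidence bearing on this result is available.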